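A few compounds are considered here, and "the series" means these few. Any claim that something is new, unique, unknown or untested is made for them only; others in the source may bear on it.

Working notes on the series, read in a functional assay on CCRF-CEM cells (Homo sapiens), read by MTT assay, with a stated time of 72 h; on this read-out higher numbers stand for weaker inhibition and lower numbers for stronger inhibition.

Compound 1, `Cc1ncnc2c1c(I)cn2[C@@H]1O[C@H](CO)[C@@H](O)[C@H]1O`, is the reference for this comparison. In this assay, among the compounds with values here, compound 1 gives 5480 nM, the only full number in the set. The two other values in the set are not numbers but limits of the assay. Compound 3, `CNc1ncnc2c1c(I)cn2[C@@H]1O[C@H](CO)[C@@H](O)[C@H]1O`, stops at a limit of the assay, > 100000 nM, which is the limit marked (the limit of > 100000 nM in this assay, at which 1 of the 3 values shown sits). Compound 2, `Nc1nc2c(c(-c3cccs3)cn2[C@@H]2O[C@H](CO)[C@@H](O)[C@H]2O)c(=O)[nH]1`, also returns only a limit, > 20000 nM, the limit marked (the limit of > 20000 nM in this assay, at which 1 of the 3 values shown sits).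

Within the data shown here, the one measured step within the set, an at least 18-fold higher number from compound 1 to compound 3 (1.26 log units; beyond the scatter), concerns a change at a different carbon of the core and does not touch the position altered here. Compound 4, `Cc1ncnc2c1c(-c1ccsc1)cn2[C@@H]1O[C@H](CO)[C@@H](O)[C@H]1O`, differs from compound 1 by thiophen-3-yl in place of iodo on an aromatic carbon. Among the measured compounds shown here, no measured pair changes this group on this core, so no measured step bears directly on the move from compound 1 to compound 4; compound 2 carries a related group at that place but on a core that differs in more than one way, so its limit is noted without being read as a step.

For compound 4 in this assay, the expected step is a 1.8-fold lower number from compound 1 to compound 4 (0.26 log units; within the scatter), and the expected value is 3000 nM, with a range from 500 nM to 20000 nM.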

Compound 4, half-maximal inhibitory concentration: 11200 nM
Beside the measured number, compound 4's estimate is 3.7-fold (0.57 log units) below it; the range from low to high includes it.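

In this assay, thiophen-3-yl in place of iodo on this aromatic carbon gives a 2.0-fold higher number from compound 1 to compound 4 (0.31 log units; beyond the scatter). Within the data shown here, this is the first measured step at this place, and it shows that the core of compound 1 keeps a full number when a single iodine gives way to an aromatic ring of five heavy atoms, although the number is modestly higher. The only other step on this core, an at least 18-fold higher number from compound 1 to compound 3 (1.26 log units; beyond the scatter), is a change at a different carbon and is larger, so the two places do not respond alike in these two pairs, and no measurement shown accounts for the size of the new step.

One step at this place cannot show whether the higher number tracks the size of the group or the identity of the ring, so a chloro group, a phenyl ring, an amine or a carboxylic acid on the same carbon remains to be placed against compound 1 and compound 4. On these data alone, it also remains open whether thiophen-3-yl would give a similar step on the methylamino core of compound 3.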